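Estimating compound 4 after removal of the amino linker

The compounds below may be only part of what the source reports. "The series", "measured", "known", "first", "only" and "open" are said of these compounds alone.

Measured so far:
Compound 1 `O=C(Nc1cccc(-n2cc(-c3ccncc3)c(-c3cc(O)cc(Cl)c3)n2)c1)Nc1ccc(Cl)c(C(F)(F)F)c1` gives 23.8% in a functional assay on SK-MEL-5 cells (Homo sapiens) for inhibition, read by sulforhodamine B assay, with a stated time of 48 h, tested at 10 uM; on this read-out lower numbers stand for a stronger effect and higher numbers for a weaker effect at the one concentration tested.
Compound 2 `O=C(Nc1cccc(-n2cc(-c3ccncc3)c(-c3cc(O)cc(Cl)c3)n2)c1)Nc1ccc(Cl)c(Cl)c1` gives -53.1% in this assay.
Compound 3 `COc1cc(Cl)cc(-c2nn(-c3cccc(NC(=O)Nc4ccc(Cl)c(C(F)(F)F)c4)c3)cc2-c2ccncc2)c1` gives -71.2% in this assay.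

Compound 3 has the lowest number of the three, and so the strongest effect in this assay; the nearest of the others is compound 2, and the furthest is compound 1. Both steps that lead away from compound 1 were large and in the same direction: a number 76.9 percentage points lower from compound 1 to compound 2 (beyond the scatter), and a number 95 percentage points lower from compound 1 to compound 3 (beyond the scatter).

Compound 4 `COc1cc(Cl)cc(-c2nn(-c3cccc(NC(=O)c4cccc(C(F)(F)F)c4)c3)cc2-c2ccncc2)c1` differs from compound 3 in one place: 3-(trifluoromethyl)phenyl in place of (4-chloro-3-(trifluoromethyl)phenyl)amino on a carbonyl carbon. Neither measured step touches this place. The step from compound 1 to compound 2 changed a group on the ring that now leaves altogether, and the step from compound 1 to compound 3 changed the other end of the molecule, so there is no direct guide. With the chloro gone and the amide-type nitrogen no longer joined to that ring, the expectation is a weaker effect than compound 3, though an uncertain one. Compound 4 is estimated at -20%, within a range of -70% to 40%. That estimate means a step of a number 51.2 percentage points higher from compound 3 to compound 4 (beyond the scatter), expected to be upward.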

Compound 4, a percentage reported as activity, at one concentration (the size of the read-out at that concentration, not a potency): 70.7%
Compound 4: the middle estimate sits 90.7 percentage points below what was measured; measured number outside the range, above it.
By their numbers in this assay, from the lowest: compound 3; then compound 2; then compound 1; then compound 4.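

In this assay, putting 3-(trifluoromethyl)phenyl in place of (4-chloro-3-(trifluoromethyl)phenyl)amino on the carbonyl carbon gives a number 141.9 percentage points higher from compound 3 to compound 4 (beyond the scatter), the largest step among the compounds shown. This shows that the group on this carbonyl carbon can decide the read-out, and that the methyl on the oxygen does not secure a low number by itself: compound 4 keeps that methyl and still loses the strong effect of compound 3. No measurement here explains why the number moves so far.

The change removes the amino nitrogen with its hydrogen and the chloro together, so the compounds shown leave open how much of the step belongs to each. Also open, on these data alone, is how this assay would respond if a methylene or an ether oxygen took the place of the amino nitrogen with the 4-chloro-3-(trifluoromethyl)phenyl group kept, or if the amino nitrogen stayed and the group on it was 3-(trifluoromethyl)phenyl.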